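Swapping a Cyclohexenyl Ring for Pyridine on the Triazole Carbon

A few compounds are considered here, and "the series" means these few. Any claim that something is new, unique, unknown or untested is made for them only; others in the source may bear on it.

Three compounds share one core and differ only in the group on an aromatic carbon of a five-membered aromatic ring with 3 nitrogen. Compound 1 `O=C1O/C(=C\Cn2cc(Cc3ccccc3)nn2)C(OCc2ccccc2)=C1OCc1ccccc1` carries a benzyl group there; in a functional assay on MDA-MB-231 cells (Homo sapiens) for antiproliferative activity, read by MTT assay, with a stated time of 24 h (a lower number here means a stronger inhibitor, a higher number a weaker inhibitor), compound 1 gives 29200 nM. Compound 2 `Cc1ccc(-c2cn(C/C=C3\OC(=O)C(OCc4ccccc4)=C3OCc3ccccc3)nn2)cc1` carries a 4-methylphenyl group. In this assay compound 2 reaches only a limit of the assay, > 100000 nM, not a number. Compound 3 `O=C1O/C(=C\Cn2cc(C3=CCCCC3)nn2)C(OCc2ccccc2)=C1OCc1ccccc1` carries a cyclohex-1-en-1-yl group. In this assay compound 3 likewise sits at a limit, > 100000 nM. Compound 3 thus stands at a limit rather than a number, the one described as the limit of > 100000 nM in this assay, at which 2 of the 3 values shown sit. The steps of an at least 3.4-fold higher number from compound 1 to compound 2 (0.53 log units; beyond the scatter) and an at least 3.4-fold higher number from compound 1 to compound 3 (0.53 log units; beyond the scatter) are both at least modest, while a step that the two limits leave unreadable from compound 2 to compound 3 cannot be read. Compound 4 `O=C1O/C(=C\Cn2cc(-c3ccccn3)nn2)C(OCc2ccccc2)=C1OCc1ccccc1` introduces (pyridin-2-yl in place of cyclohex-1-en-1-yl on an aromatic carbon). Within the data shown here, no measured compound shows the effect of a pyridine here; both replacements of benzyl by a ring gave limits. For compound 4 the expected value in this assay is 100000 nM, estimated to lie between 30000 nM and 300000 nM. This estimate means a step of a number no higher from compound 3 to compound 4 (the limit leaves the size open) that is expected to stay within the scatter.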

Compound 4, half-maximal inhibitory concentration: > 100000 nM
Compound 4 was reported as a limit; the forecaster's own chance of this, stated with the estimate: 60%; the middle value sits exactly at the limit.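

Pyridin-2-yl in place of benzyl on this aromatic carbon gives an at least 3.4-fold higher number from compound 1 to compound 4 (0.53 log units; beyond the scatter) in this assay, so a ring bearing a nitrogen and a hydrogen-bond acceptor does not restore a readable number here. Compound 4 gives > 100000 nM, which is a limit of the assay and not a number. The steps among compound 2, compound 3 and compound 4 cannot be read, and compound 1 remains the only one of the four with a number, while the other three share one ceiling: the limit of > 100000 nM in this assay, at which 3 of the 4 values shown sit.

As far as these compounds go, how far compound 2, compound 3 and compound 4 lie from one another stays open. Also open, from the compounds shown here alone, is whether a pyridin-2-ylmethyl group or a longer chain such as 2-phenylethyl on this carbon would give a number.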